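Adding a methoxy to compound 2

The source may hold more compounds than are shown below. What is called first, only, known or untested is meant among the compounds shown, and "the series" means these compounds.

Of the compounds shown here, three sharing one core have been measured in a functional assay on HepG2 cells (Homo sapiens) for inhibition, read by MTT assay, with a stated time of 24 h; on this read-out higher numbers stand for weaker inhibition of growth and lower numbers for stronger inhibition of growth. Compound 1 (`COc1ccc(C(=O)n2c(-c3cn(C)c4ccccc34)nc3ccccc32)cc1`) gives 15200 nM, compound 2 (`COc1ccc(C(=O)n2c(-c3cn(C)c4ccccc34)nc3ccccc32)cc1OC`) gives 8400 nM, and compound 3 (`Cn1cc(-c2nc3ccccc3n2C(=O)c2cccc(Br)c2)c2ccccc21`) gives 61400 nM. Compound 2 thus stands level with compound 1 at the low end of these numbers, the step between them being a 1.8-fold lower number from compound 1 to compound 2 (0.26 log units; within the scatter). Two larger steps lead away from that pair: a 4.0-fold higher number from compound 1 to compound 3 (0.61 log units; beyond the scatter), and a 7.3-fold higher number from compound 2 to compound 3 (0.86 log units; beyond the scatter).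

Compound 4 (`COc1ccc2c(c1)c(-c1nc3ccccc3n1C(=O)c1ccc(OC)c(OC)c1)cn2C`) alters compound 2 in one place: methoxy in place of hydrogen on an aromatic carbon. The new methoxy replaces hydrogen on an aromatic carbon, part of a fused or bridged system of two rings. For the measured compounds named here, no measured compound carries a group on that ring, so the evidence is indirect. The nearest guide is the same kind of swap made elsewhere in compound 2, which was a 1.8-fold lower number from compound 1 to compound 2 (0.26 log units; within the scatter). The steps to compound 3 exchange a whole group on a carbonyl carbon and say little here. No step beyond the scatter is therefore expected in this assay, with only a slight lean towards a lower number. The expected step is a 1.2-fold lower number from compound 2 to compound 4 (0.08 log units; within the scatter). Compound 4 is estimated at 7000 nM, with an expected range from 2800 nM to 18000 nM.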

Compound 4, concentration for 50% growth inhibition: 5100 nM
The estimate for compound 4 lay 1.4-fold (0.14 log units) above the measured number; low and high end bracket the measured number.
By their numbers in this assay, from the lowest: compounds 4, 2 and 1 (each within the scatter of the next, the first and the last beyond it); then compound 3.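

For the compounds shown here, compound 4 gives the first direct reading on this ring, and in this assay the methoxy on an aromatic carbon of the six-membered aromatic ring of carbon only, meta to a fused ring and para to a fused ring, produces a 1.6-fold lower number from compound 2 to compound 4 (0.22 log units; within the scatter), so this position accepts the group with no change that can be told from scatter. The same swap of methoxy for hydrogen at the other end of the molecule, seen as a 1.8-fold lower number from compound 1 to compound 2 (0.26 log units; within the scatter), also stayed within the scatter, which means that among these compounds neither of the two places has yet given a methoxy step that can be read as a real change, while the one step that moved the number beyond the scatter were those replacing a whole group on the carbonyl carbon. The data offer nothing that bears on why this position accepts the methoxy.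

Going by these compounds, whether an amine, a carboxylic acid or a longer chain such as butoxy on this same carbon would also stay within the scatter of compound 2 remains open. Also open, on these data alone, is whether this methoxy would leave the number equally unmoved with the 3-bromophenyl group of compound 3 on the carbonyl carbon.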